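The compounds below may be only part of what the source reports. "The series", "measured", "known", "first", "only" and "open" are said of these compounds alone.

Measured so far:
compound 1 `O=C(c1ccccc1)N(C(=O)c1ccccc1)c1nccn2cc(-c3ccccc3)nc12`: 64 nM
compound 2 `COc1ccc(C(=O)Nc2nc(-c3ccccc3)cn3cc(-c4ccccc4)nc23)cc1`: 25 nM
compound 3 `Cc1ccc(C(=O)Nc2nc(-c3ccccc3)cn3cc(-c4ccccc4)nc23)cc1`: 223 nM

In an assay on cells for displacement of a labelled ligand from transmembrane domain-containing protein TMIGD3 (Homo sapiens), read by scintillation counting, with a stated time of 120 min (a higher number here means a weaker inhibitor, a lower number a stronger inhibitor), compound 2 gives the lowest of these three numbers; compound 1 stands closest to it and compound 3 furthest. Going by the values given here, the only step measured between two compounds that differ in one place is an 8.9-fold higher number from compound 2 to compound 3 (0.95 log units; beyond the scatter), a swap of methyl for methoxy on an aromatic carbon.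

Compound 4 `O=C(Nc1nc(-c2ccccc2)cn2cc(-c3ccccc3)nc12)c1ccco1` differs from compound 2 by furan-2-yl in place of 4-methoxyphenyl on a carbonyl carbon. Among the compounds with values here, the group that leaves is the one carrying the methoxy, so the one measured step that bears on this change, an 8.9-fold higher number from compound 2 to compound 3 (0.95 log units; beyond the scatter), also removed that methoxy and gave a higher number. A rise of similar, modest size in this assay is therefore expected. For compound 4 the estimated value is 150 nM, in a range from 45 nM to 500 nM. This estimate corresponds to an expected 6.0-fold higher number from compound 2 to compound 4 (0.78 log units; beyond the scatter).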

Compound 4, inhibition constant: 67 nM
Compound 4: middle estimate off by 2.2-fold (0.35 log units), on the high side; the range from low to high includes it.
By their numbers in this assay, from the lowest: compound 2; then compounds 1 and 4 (each within the scatter of the next); then compound 3.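

At this carbonyl carbon, the five-membered furan-2-yl, with its smaller heavy-atom count, is accepted without a six-membered ring: it gives a weaker result than 4-methoxyphenyl (a 2.7-fold higher number from compound 2 to compound 4 (0.43 log units; beyond the scatter)) but a stronger one than 4-methylphenyl (a 3.3-fold lower number from compound 3 to compound 4 (0.52 log units; beyond the scatter)). Losing the methoxy therefore does not by itself set the number, since the two compounds without it, compound 3 and compound 4, differ beyond the scatter. The compounds shown leave open how a plain phenyl, a thiophen-2-yl or a saturated cyclohexyl would compare on this carbonyl carbon. Nothing available explains the order of these three groups.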